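Trifluoromethyl in place of chloro: notes on compound 4

The source may hold more compounds than are shown below. What is called first, only, known or untested is meant among the compounds shown, and "the series" means these compounds.

Measured in a functional assay on HepG2 cells (Homo sapiens) for inhibition, read by MTT assay, with a stated time of 72 h; a higher number here means a weaker inhibitor, a lower number a stronger inhibitor:
compound 1 `COc1ccc(/C=C/C(=O)c2c(OC)cc(O)c(CC=C(C)C)c2O)cc1`: 32400 nM
compound 2 `COc1cc(O)c(CC=C(C)C)c(O)c1C(=O)/C=C/c1ccc(O)c(O)c1`: 15200 nM
compound 3 `COc1cc(O)c(CC=C(C)C)c(O)c1C(=O)/C=C/c1ccc(Cl)cc1`: 10100 nM

Compound 3 stands at 10100 nM with no gap beyond the scatter to its nearest neighbour (a 1.5-fold lower number from compound 2 to compound 3 (0.18 log units; within the scatter)). Its clear gap is on the other side (a 3.2-fold lower number from compound 1 to compound 3 (0.51 log units; beyond the scatter)). That step is the closest evidence, as it is a change on the same aromatic carbon and is modest. The other step beyond the scatter is also modest (a 2.1-fold lower number from compound 1 to compound 2 (0.33 log units; beyond the scatter)).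

Compound 4 `COc1cc(O)c(CC=C(C)C)c(O)c1C(=O)/C=C/c1ccc(C(F)(F)F)cc1` carries trifluoromethyl in place of chloro on an aromatic carbon. Among the measured compounds shown here, no measured compound carries trifluoromethyl, so no measured step shows this change directly, and the data give no direction for it. In this assay no step beyond the scatter is therefore expected, and a modest step either way remains possible. The expected step is small (a 1.0-fold lower number from compound 3 to compound 4 (0.00 log units; within the scatter)). For compound 4 the estimated value is 10000 nM (expected range 5000 nM to 20000 nM).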

Compound 4, half-maximal inhibitory concentration: 6500 nM
Compound 4: middle estimate off by 1.5-fold (0.19 log units), on the high side; measured number inside the range.
By their numbers in this assay, from the lowest: compounds 4, 3 and 2 (each within the scatter of the next, the first and the last beyond it); then compound 1.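

In this assay, the exchange of chloro (1 heavy atom) for trifluoromethyl (4 heavy atoms) on this aromatic carbon, para to a large group, gives a 1.6-fold lower number from compound 3 to compound 4 (0.19 log units; within the scatter), so compound 3 and compound 4 cannot be told apart here. This position therefore accepts trifluoromethyl as well as chloro without a step beyond the scatter, and the clear step from methoxy seen with chloro also appears with trifluoromethyl, as a 5.0-fold lower number from compound 1 to compound 4 (0.70 log units; beyond the scatter). No measurement shown here bears on what lies behind these steps.

Still open, from the compounds shown here alone, is how an amine, a carboxylic acid or a nitrile on this aromatic carbon would compare with chloro and trifluoromethyl. The compounds shown also leave open whether this pattern holds outside this one assay.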